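Decanoyl and stearoyl amide nucleosides in a cytotoxicity assay

The source may report more compounds than this note shows. Statements on the series, on what has been measured and on what is new or still open speak of the compounds shown alone.

Compounds measured so far:
compound 1, `CCCCCCCCCCCCCCCCCC(=O)N[C@@H](CCSC)C(=O)Nc1ccn([C@H]2O[C@@H](CO)[C@H](O)[C@H]2O)c(=O)n1`: 9000 nM
compound 2, `CCCCCCCCCCCCCCCCCC(=O)N[C@@H](CCC(=O)O)C(=O)Nc1ccn([C@H]2O[C@@H](CO)[C@H](O)[C@H]2O)c(=O)n1`: 19000 nM
compound 3, `CCCCCCCCCC(=O)N[C@@H](CCC(=O)O)C(=O)Nc1ccn([C@H]2O[C@@H](CO)[C@H](O)[C@H]2O)c(=O)n1`: 5000 nM

In a functional assay on HeLa cells (Homo sapiens) for cytotoxicity, read by MTT assay, with a stated time of 48 h (on this read-out lower numbers stand for stronger inhibition and higher numbers for weaker inhibition), compound 2 gives 19000 nM and compound 1 gives 9000 nM. The change between them is methylsulfanyl in place of carboxy on a saturated chain carbon, three bonds along the chain from an amide-type nitrogen and a carbonyl carbon, and the step it made is a 2.1-fold lower number from compound 2 to compound 1 (0.32 log units; beyond the scatter). Compound 3 gives 5000 nM in this assay; its core differs from that of compound 2 by hydrogen in place of octyl on a saturated chain carbon, nine bonds along the chain from a carbonyl carbon, with a 3.8-fold lower number from compound 2 to compound 3 (0.58 log units; beyond the scatter). Compound 1 and compound 3 lie within the scatter of each other.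

Compound 4, `CCCCCCCCCC(=O)N[C@@H](CCSC)C(=O)Nc1ccn([C@H]2O[C@@H](CO)[C@H](O)[C@H]2O)c(=O)n1`, is not yet measured. Going by the values given here, it differs from compound 3 by methylsulfanyl in place of carboxy on a saturated chain carbon, three bonds along the chain from an amide-type nitrogen and a carbonyl carbon, the same change as the one from compound 2 to compound 1, on the same place. If it carries over onto the core of compound 3, a step of about the same size is expected, namely a 2.1-fold lower number from compound 3 to compound 4 (0.32 log units; beyond the scatter), resting on the single earlier example a 2.1-fold lower number from compound 2 to compound 1 (0.32 log units; beyond the scatter) and on compound 3 at 5000 nM. Compound 4 is therefore estimated at 2400 nM in this assay, between 1000 nM and 6000 nM.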

Compound 4, half-maximal inhibitory concentration: 3000 nM
Compound 4: middle estimate off by 1.3-fold (0.10 log units), on the low side, within the range that was stated.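

In this assay, methylsulfanyl in place of carboxy gives a 1.7-fold lower number from compound 3 to compound 4 (0.22 log units; within the scatter), and this step agrees with the one seen on the stearoyl core: the same change on two cores in this assay, a 2.1-fold lower number (0.32 log units; beyond the scatter) from compound 2 to compound 1 and a 1.7-fold lower number (0.22 log units; within the scatter) from compound 3 to compound 4, 1.3-fold (0.10 log units) apart, within the scatter of two such steps. Hydrogen in place of octyl on a saturated chain carbon, nine bonds along the chain from a carbonyl carbon, gives a 3.0-fold lower number from compound 1 to compound 4 (0.48 log units; beyond the scatter), which likewise agrees with the step seen in the carboxy pair: the same change on two cores in this assay, a 3.8-fold lower number (0.58 log units; beyond the scatter) from compound 2 to compound 3 and a 3.0-fold lower number (0.48 log units; beyond the scatter) from compound 1 to compound 4, 1.3-fold (0.10 log units) apart, within the scatter of two such steps. Both changes therefore carried over between these two cores at about the same size, although the methylsulfanyl step on the core of compound 3 does not clear the scatter on its own, and a single pair of cores for each change establishes no general rule.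

On these data alone, it remains open whether the same steps would hold with an amine or a hydroxyl group in place of the methylsulfanyl group. As far as these compounds go, it also remains open how a hexanoyl chain or an icosanoyl chain would compare with the decanoyl and stearoyl chains.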